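Imidazoline aryl ethers: methylfuran in place of thiophene

A few compounds are considered here, and "the series" means these few. Any claim that something is new, unique, unknown or untested is made for them only; others in the source may bear on it.

Measured in a functional assay for activation of Alpha-1D adrenergic receptor (Homo sapiens), read by calcium flux; a higher number here means that more compound is needed for the effect, a lower number that less compound is needed:
- compound 1, `CCN(CC)C(=O)c1ccccc1OCC1=NCCN1`: < 5020 nM, a limit
- compound 2, `Cc1ccnc(-c2ccccc2OCC2=NCCN2)c1`: < 100000 nM, a limit
- compound 3, `c1csc(-c2ccccc2OCC2=NCCN2)c1`: 15.9 nM

Going by the values given here, compound 3 is the only member with a number in this assay. Compound 1 sits at a limit, (the limit of < 5020 nM in this assay, at which 1 of the 3 values shown sits). Compound 2 sits at a different limit, (the limit of < 100000 nM in this assay, at which 1 of the 3 values shown sits). Among the compounds with values here, no step between two measured compounds can be read from these three, since no pair differs in one place, and the two limits give no size for any comparison with compound 3.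

Compound 4, `Cc1ccoc1-c1ccccc1OCC1=NCCN1`, differs from compound 3 in one place: 3-methylfuran-2-yl in place of thiophen-2-yl on an aromatic carbon. Both groups are five-membered aromatic rings with one hetero atom and one hydrogen-bond acceptor, the entering group carrying one more carbon as a methyl. Within the data shown here, with no measured step to lean on, the expected step from compound 3 to compound 4 is small, a 2.5-fold higher number from compound 3 to compound 4 (0.40 log units; beyond the scatter), towards a somewhat higher number but not clearly beyond the scatter. Compound 4 is therefore estimated at 40 nM, with a range from 8 nM to 200 nM.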

Compound 4, half-maximal effective concentration: < 100000 nM
Compound 4: no number, only a limit; the forecaster's own chance of this, stated with the estimate: 5%; the middle value is on the limit's open side.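

In this assay compound 4 gives < 100000 nM, which is a limit and not a number: the limit of < 100000 nM in this assay, at which 2 of the 4 values shown sit.

Going by these compounds alone, no step from compound 3 to compound 4 can be read. Still open, as far as these compounds go, is how large the change is on placing 3-methylfuran-2-yl in place of thiophen-2-yl.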